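Aryl-amine sulfone series: methoxy to trifluoromethyl swap

The source may report more compounds than this note shows. Statements on the series, on what has been measured and on what is new or still open speak of the compounds shown alone.

The series shares one core, to which an aniline-type aryl ring is attached through a nitrogen. Compound 1 `O=S1(=O)C=Cc2cccc(Nc3ccc(C(F)(F)F)cc3)c21` carries a trifluoromethyl group on that ring, compound 2 `COc1ccc(Nc2cccc3c2S(=O)(=O)C=C3)cc1` a methoxy group in the matching position, and compound 3 `COc1ccccc1Nc1cccc2c1S(=O)(=O)C=C2` a methoxy group in a different position. In a functional assay on HCT-116 cells (Homo sapiens) for antiproliferative activity, read by MTT assay, with a stated time of 72 h (a higher number here means a weaker inhibitor, a lower number a stronger inhibitor), compound 1 gives 1440 nM, compound 2 gives 1990 nM, and compound 3 gives 5000 nM. The difference between compound 2 and compound 3 is not broken down here; their two values show compound 3 with the higher number, and that gap lies beyond the scatter.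

Among the measured compounds shown here, the one measured step that swaps the groups is trifluoromethyl in place of methoxy on an aromatic carbon, which gave a 1.4-fold lower number from compound 2 to compound 1 (0.14 log units; within the scatter). Compound 4 `O=S1(=O)C=Cc2cccc(Nc3ccccc3C(F)(F)F)c21` is not yet measured; it arises from compound 3 by trifluoromethyl in place of methoxy on an aromatic carbon. The surroundings differ: the swap in compound 1 sits para to a large group, whereas in compound 4 it sits ortho to a large group, so this is the same kind of change, not the same change.

In this assay the step from compound 3 to compound 4 is expected to be small, a 1.4-fold lower number from compound 3 to compound 4 (0.14 log units; within the scatter), resting on the near-flat step a 1.4-fold lower number from compound 2 to compound 1 (0.14 log units; within the scatter) and on the starting point set by compound 3 with 5000 nM. Compound 4 is therefore estimated at 3600 nM, with a likely range from 1800 nM to 7200 nM.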

Compound 4, half-maximal inhibitory concentration: 5950 nM
The estimate for compound 4 lay 1.7-fold (0.22 log units) below the measured number; measured number inside the range.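

In this assay, trifluoromethyl in place of methoxy, ortho to a large group, gave a 1.2-fold higher number from compound 3 to compound 4 (0.08 log units; within the scatter) and so left the number in the same range as the starting compound. Set beside the earlier step, the new one does not separate from it, and in both pairs the swap stays small: the same change on two cores in this assay, a 1.4-fold lower number (0.14 log units; within the scatter) from compound 2 to compound 1 and a 1.2-fold higher number (0.08 log units; within the scatter) from compound 3 to compound 4, 1.6-fold (0.22 log units) apart, within the scatter of two such steps. This shows that, across these two pairs only, the exchange of methoxy for trifluoromethyl carried over without a step beyond the scatter, but it does not show that the two groups are interchangeable in general or that a step this small would hold on any further core, since two pairs are too few to support a rule and the small steps give no direction that could be carried over.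

The compounds shown leave open how the ring would respond to groups of another kind in the same places, such as an amine, a carboxylic acid or a nitrile. Also open, as far as these compounds go, is what a change at the linking nitrogen, such as a methyl group on it, or a substituent on the shared core itself would do to the numbers.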